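A Hydroxy Core Meets the Dimethoxyphenyl Switch

The compounds below may be only part of what the source reports. "The series", "measured", "known", "first", "only" and "open" are said of these compounds alone.

Of the compounds shown here, three sharing one core have been measured in a functional assay on A549 cells (Homo sapiens) for inhibition, read by sulforhodamine B assay; on this read-out lower numbers stand for stronger inhibition of growth and higher numbers for weaker inhibition of growth. Compound 1 `Clc1cccc(-c2ccc(-c3ccc(-c4nc5ccccc5[nH]4)cc3)cc2)c1` gives 31100 nM. Compound 2 `COc1ccc(-c2ccc(-c3ccc(-c4nc5ccccc5[nH]4)cc3)cc2)cc1OC` gives 7600 nM. Compound 3 `Oc1cccc2[nH]c(-c3ccc(-c4ccc(-c5cccc(Cl)c5)cc4)cc3)nc12` gives 2400 nM, the lowest of the three. Compound 4 `COc1ccc(-c2ccc(-c3ccc(-c4nc5c(O)cccc5[nH]4)cc3)cc2)cc1OC` has not been measured.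

Between compound 1 and compound 2 the change is 3,4-dimethoxyphenyl in place of 3-chlorophenyl on an aromatic carbon, and it produced a 4.1-fold lower number from compound 1 to compound 2 (0.61 log units; beyond the scatter). Compound 3 differs from compound 1 in its core: hydroxy in place of hydrogen on an aromatic carbon, a change that brought a 13-fold lower number from compound 1 to compound 3 (1.11 log units; beyond the scatter). Compound 4 carries the core of compound 3 together with the change (3,4-dimethoxyphenyl in place of 3-chlorophenyl on an aromatic carbon), the same change already seen between compound 1 and compound 2, at a place described in the same words.

Among the compounds with values here, only one example of that change is known, so its effect on the core of compound 3 is taken with some caution. Compound 4 is nevertheless expected to show a 3.4-fold lower number from compound 3 to compound 4 (0.54 log units; beyond the scatter), a step kept a little smaller than the one recorded earlier. Compound 4 is estimated at 700 nM, with a likely span from 250 nM to 2000 nM.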

Compound 4, concentration for 50% growth inhibition: 1310 nM
Estimate against measurement, compound 4: 1.9-fold (0.27 log units) below, within the range that was stated.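

In this assay, 3,4-dimethoxyphenyl in place of 3-chlorophenyl on the core of compound 3 gave a 1.8-fold lower number from compound 3 to compound 4 (0.26 log units; within the scatter), a step that cannot be told from no change on its own, yet it also cannot be told apart from the step seen for the same change on the core of compound 1: the same change on two cores in this assay, a 4.1-fold lower number (0.61 log units; beyond the scatter) from compound 1 to compound 2 and a 1.8-fold lower number (0.26 log units; within the scatter) from compound 3 to compound 4, 2.2-fold (0.35 log units) apart, within the scatter of two such steps
Hydroxy in place of hydrogen, read the other way round, gave a 5.8-fold lower number from compound 2 to compound 4 (0.76 log units; beyond the scatter), which stays beyond the scatter and agrees with its earlier counterpart on the core of compound 1: the same change on two cores in this assay, a 13-fold lower number (1.11 log units; beyond the scatter) from compound 1 to compound 3 and a 5.8-fold lower number (0.76 log units; beyond the scatter) from compound 2 to compound 4, 2.2-fold (0.35 log units) apart, within the scatter of two such steps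
Within these four compounds, both changes therefore carry over from one core to the other without a detectable difference, but a single pair of steps for each change, in a single assay, does not show that the two changes would combine in the same way on any other core.

On these data alone, it remains open whether an amine or a methoxy group in place of the hydroxy would give a comparable step. Also open, as far as these compounds go, is whether an aminophenyl or a carboxyphenyl group in place of the 3,4-dimethoxyphenyl would carry over between these cores in the same way.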